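The compounds below may be only part of what the source reports. "The series", "measured", "known", "first", "only" and "open" are said of these compounds alone.

For the measured compounds named here, in a functional assay on HCT-116 cells (Homo sapiens) for cytotoxicity, read by MTT assay, with a stated time of 72 h (a higher number here means a weaker inhibitor, a lower number a stronger inhibitor), compound 1 (`O=S(=O)(c1ccccc1)c1nc2ccccc2nc1N1CCCC1`) gives 24200 nM as the only actual number so far. Compound 2 (`Cc1ccc(S(=O)(=O)c2nc3ccccc3nc2N2CCCC2)cc1`) reads > 50000 nM as a limit of the assay. Going by the values given here, compound 2 supplies the single measured step (an at least 2.0-fold higher number from compound 1 to compound 2 (0.31 log units; beyond the scatter)) with methyl in place of hydrogen on an aromatic carbon, a different change at a different place. Compound 3 (`O=S(=O)(c1ccccc1)c1nc2ccccc2nc1N1CCCC(O)C1`) has 3-hydroxypiperidin-1-yl in place of pyrrolidin-1-yl on an aromatic carbon. With compound 1 at 24200 nM as the anchor, no shift beyond the scatter is expected (a 1.2-fold higher number from compound 1 to compound 3 (0.06 log units; within the scatter)) in this assay. Compound 3 is estimated at 28000 nM with an expected range from 10000 nM to 50000 nM for now.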

Compound 3, half-maximal inhibitory concentration: 1390 nM
The estimate for compound 3 lay 20-fold (1.30 log units) above the measured number; the measured number lies below the stated range.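

The position carrying pyrrolidin-1-yl responds strongly in this assay: 3-hydroxypiperidin-1-yl there gives a 17-fold lower number from compound 1 to compound 3 (1.24 log units; beyond the scatter), the only step shown towards a lower number. Both ends of this step are actual numbers, so its size can be read in full. Nothing in the data shown accounts for a step of this size. The change enlarges the ring and adds a hydroxyl in one move, and the compounds shown do not separate the two. An unsubstituted piperidine and a hydroxyl-bearing pyrrolidine at this position would divide the step between them.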